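Working notes: removing the dimethylpyrazole from compound 2

This account rests on a few compounds, and the source may have more. Where it says the series, first, only, none or still open, it means among the compounds named here.

- compound 1 `CC(C)Oc1cc(-c2cncc(-c3cnn(C4COC4)c3)c2)ccc1C(N)=O` gives 3.1 mL.min-1.g-1
- compound 2 `Cc1c(-c2cncc(-c3ccc(C(N)=O)c(OC(C)C)c3)c2)cnn1C` gives 25.1 mL.min-1.g-1

Compound 2 holds the higher of the two numbers in an ADME assay on microsomes from liver (Mus musculus) for pharmacokinetics (on this read-out lower numbers stand for slow clearance and higher numbers for fast clearance), so far. Compound 3 `CC(C)Oc1cc(-c2cccnc2)ccc1C(N)=O` differs from compound 2 by hydrogen in place of 1,5-dimethyl-1H-pyrazol-4-yl on an aromatic carbon and so has hydrogen in place of 1,5-dimethyl-1H-pyrazol-4-yl on an aromatic carbon. Among the compounds with values here, no measured step removes such a group, so the one step of an 8.1-fold higher number from compound 1 to compound 2 (0.91 log units; beyond the scatter) gives only a rough guide to size: a similar or smaller change is expected, tentatively downward. The expected move is a 2.1-fold lower number from compound 2 to compound 3 (0.32 log units; beyond the scatter) in this assay and remains uncertain. For compound 3 the estimated value is 12 mL.min-1.g-1 with an expected range from 4 mL.min-1.g-1 to 35 mL.min-1.g-1 on this read-out.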

Compound 3, intrinsic clearance in microsomes: 9.4 mL.min-1.g-1
Compound 3: the middle estimate sits 1.3-fold (0.11 log units) above what was measured; the range from low to high includes it.
By their numbers in this assay, from the lowest: compound 1; then compound 3; then compound 2.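

In this assay hydrogen in place of 1,5-dimethyl-1H-pyrazol-4-yl gives a 2.7-fold lower number from compound 2 to compound 3 (0.43 log units; beyond the scatter) and hydrogen in place of 1-(oxetan-3-yl)-1H-pyrazol-4-yl gives a 3.0-fold higher number from compound 1 to compound 3 (0.48 log units; beyond the scatter) on the same aromatic carbon. The direction of the change at this position therefore depends on which group leaves, and compound 3 lies between the two pyrazole compounds. Nothing available explains either direction.

Open, on these data alone, is where a smaller group on this carbon, such as an amine or a methoxy group, would fall relative to compound 3.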